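Benzylic amine in place of silylmethyl on the furopyridine core

This account rests on a few compounds, and the source may have more. Where it says the series, first, only, none or still open, it means among the compounds named here.

Measured compounds:
- compound 1, `CCOC(=O)CNc1oc2c(C)ncc(CO)c2c1Nc1ccccn1`: "not active" (no number reported) in a functional assay on HEK293 cells for agonist activity at Toll-like receptor 8 (Homo sapiens), read by reporter gene assay; a higher number here means that more compound is needed for the effect, a lower number that less compound is needed
- compound 2, `Cc1ncc(CO)c2c(Nc3ccccn3)c(NC[Si](C)(C)C)oc12`: 4990 nM in this assay

Going by the values given here, compound 2 carries the only number reported in this assay: compound 2 gives 4990 nM. Among the compounds with values here, compound 1 stands beside it without a number, reported in this assay only as "not active" (no number reported), so no step between measured compounds can be sized, and the position of compound 2 among its neighbours is simply that of the one quantified entry.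

Compound 3, `Cc1ncc(CO)c2c(Nc3ccccn3)c(N[C@@H](C)c3ccccc3)oc12`, has not yet been measured. Relative to compound 2 the change is a group of 8 heavy atoms (8 carbon; one six-membered aromatic ring of carbon only) in place of a group of 5 heavy atoms (4 carbon, 1 silicon; no ring), on a nitrogen on an aromatic ring. Both groups carry no donors or acceptors, so the difference lies in the ring-bearing, stereodefined 1-phenylethyl group replacing an acyclic silicon-containing chain on the same ring nitrogen.

Within the data shown here, with no measured step to lean on, the expected step from compound 2 to compound 3 is a moderate gain, a 3.3-fold lower number from compound 2 to compound 3 (0.52 log units; beyond the scatter), somewhat beyond the scatter but not dramatic. Compound 3 is therefore estimated at 1500 nM in this assay, with a plausible range from 300 nM to 6000 nM.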

Compound 3, half-maximal effective concentration: 4270 nM
Compound 3: the middle estimate sits 2.8-fold (0.45 log units) below what was measured; measured number inside the range.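

In this assay, placing 1-phenylethyl on the nitrogen on an aromatic ring, in place of the acyclic silicon-containing group, gives a 1.2-fold lower number from compound 2 to compound 3 (0.07 log units; within the scatter), so compound 2 and compound 3 cannot be told apart. This first readable step shows that, at this position and in this assay, an aromatic ring and a defined stereocentre can enter while a numerical response is retained, and that the silicon atom of compound 2 is not needed for such a response, as compound 3 contains none. Compound 1 remains reported as "not active" (no number reported), so steps to it cannot be read, and nothing available explains why the two quantified compounds are so similar.

The compounds shown leave open whether the stereocentre matters, which the mirror-image 1-phenylethyl group or a plain benzyl group would address, and whether the silicon-containing group behaves differently from its all-carbon counterpart, neopentyl. They also leave open whether a ring-bearing group with a polar substituent, such as a 4-hydroxyphenyl ring or a pyridine ring in place of the phenyl ring, would shift the number beyond the usual scatter.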